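The compounds below may be only part of what the source reports. "The series", "measured", "known", "first", "only" and "open" are said of these compounds alone.

So far only two compounds have been measured in a physicochemical assay for solubility, read by HPLC, in phosphate buffer, measured as kinetic solubility, at pH 7.4 (on this read-out lower numbers stand for lower solubility and higher numbers for higher solubility), and they share one core. Compound 1 `CCC(=O)c1cc(-c2ccc(S(N)(=O)=O)cc2)n(-c2ccc(C(F)(F)F)cc2)n1` gives 7500 nM, and compound 2 `CCC(=O)c1cc(-c2ccc(S(N)(=O)=O)cc2)n(-c2cccc(Cl)c2)n1` gives 6900 nM. These two numbers lie within the scatter of each other, meaning that repeat measurements of a single compound could differ by as much, so compound 2 cannot be told apart from compound 1 on this read-out. The next structure is compound 3 `CCC(=O)c1cc(-c2ccc(S(N)(=O)=O)cc2)n(-c2ccc(OC)cc2)n1`, which keeps the shared core. In going from compound 2 to compound 3, 4-methoxyphenyl takes the place of 3-chlorophenyl on an aromatic nitrogen (4-methoxyphenyl in place of 3-chlorophenyl on an aromatic nitrogen). Among the measured compounds shown here, no measured pair yet shows what this exchange does in this assay, so no step beyond the scatter is expected, with only a slight lean towards a higher number. For the measured compounds named here, the starting point is compound 2 at 6900 nM, and the only other reference is compound 1 at 7500 nM. The estimated step is a 1.3-fold higher number from compound 2 to compound 3 (0.12 log units; within the scatter), which is expected to stay within the scatter. For compound 3 the expected value is 9000 nM, with an estimated range from 4000 nM to 20000 nM.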

Compound 3, solubility: 64300 nM
Compound 3: the middle estimate sits 7.1-fold (0.85 log units) below what was measured; the measured number lies above the stated range.
By their numbers in this assay, from the lowest: compounds 2 and 1 (each within the scatter of the next); then compound 3.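

In this assay the group on the aromatic nitrogen turns out to be able to move the read-out well beyond the scatter: 4-methoxyphenyl in place of 3-chlorophenyl gives a 9.3-fold higher number from compound 2 to compound 3 (0.97 log units; beyond the scatter) while compound 1 and compound 2, with their different groups at this position, could not be told apart. Methoxy in place of trifluoromethyl on an aromatic carbon of that same ring gives an 8.6-fold higher number from compound 1 to compound 3 (0.93 log units; beyond the scatter) and isolates the change to one group, so compound 3 stands apart from both earlier compounds, not just from one of them. Nothing measured here explains why this exchange gives so large a step.

On these data alone, with a single methoxy compound, it remains open whether the step belongs to methoxy as such or also to where it sits, and 3-methoxyphenyl would separate those two readings. As far as these compounds go, it is also open whether the step persists with a longer chain on the oxygen, as in 4-ethoxyphenyl, or with an amine in place of methoxy, as in 4-aminophenyl.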